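Indolyl naphthoquinone methanes: cytotoxicity and a methoxyphenyl variant

The compounds below may be only part of what the source reports. "The series", "measured", "known", "first", "only" and "open" are said of these compounds alone.

Measured compounds:
compound 1 `COc1ccccc1C(C1=C(O)C(=O)c2ccccc2C1=O)c1c[nH]c2ccccc12`: 128000 nM
compound 2 `COc1ccc(C(C2=C(O)C(=O)c3ccccc3C2=O)c2c[nH]c3ccccc23)cc1Br`: 7320 nM
compound 3 `O=C1C(O)=C(C(c2ccc([N+](=O)[O-])cc2)c2c[nH]c3ccccc23)C(=O)c2ccccc21`: 14800 nM

Three compounds share a core and differ only in the aryl group on a saturated chain carbon bound to an aromatic carbon and a double-bonded ring carbon. In a functional assay on HeLa cells (Homo sapiens) for cytotoxicity, read by MTT assay, with a stated time of 48 h (on this read-out lower numbers stand for stronger inhibition and higher numbers for weaker inhibition), compound 3 gives 14800 nM, the second highest of the three numbers; its nearest neighbour is compound 2, with a 2.0-fold higher number from compound 2 to compound 3 (0.31 log units; beyond the scatter), and its furthest is compound 1, with an 8.6-fold lower number from compound 1 to compound 3 (0.94 log units; beyond the scatter). Compound 4 `COc1cccc(C(C2=C(O)C(=O)c3ccccc3C2=O)c2c[nH]c3ccccc23)c1` has not been measured. It differs from compound 3 by 3-methoxyphenyl in place of 4-nitrophenyl on a saturated chain carbon bound to an aromatic carbon and a double-bonded ring carbon. Among the compounds with values here, no measured step swaps a nitro group for a methoxy group at this place; the steps that bear on it are an 8.6-fold lower number from compound 1 to compound 3 (0.94 log units; beyond the scatter) and a 17-fold lower number from compound 1 to compound 2 (1.24 log units; beyond the scatter), both of which show that a methoxyphenyl lacking a further substituent gives the highest number of the set. A modest rise is therefore expected for compound 4, a 2.7-fold higher number from compound 3 to compound 4 (0.43 log units; beyond the scatter). Compound 4 is estimated at 40000 nM, within 10000 nM to 150000 nM.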

Compound 4, half-maximal inhibitory concentration: 25600 nM
Estimate against measurement, compound 4: 1.6-fold (0.19 log units) above; low and high end bracket the measured number.
By their numbers in this assay, from the lowest: compound 2; then compounds 3 and 4 (each within the scatter of the next); then compound 1.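

In this assay, a methoxyphenyl lacking a further substituent does not by itself go with a high number: 3-methoxyphenyl in place of 2-methoxyphenyl gives a 5.0-fold lower number from compound 1 to compound 4 (0.70 log units; beyond the scatter), so the result depends on where the methoxy group stands on the aryl ring. 3-Methoxyphenyl in place of 4-nitrophenyl gives a 1.7-fold higher number from compound 3 to compound 4 (0.24 log units; within the scatter), so these two groups cannot be told apart here, whereas 3-methoxyphenyl in place of 3-bromo-4-methoxyphenyl gives a 3.5-fold higher number from compound 2 to compound 4 (0.54 log units; beyond the scatter), and compound 2 keeps the lowest number of the four. Nothing available explains any of these differences.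

The compounds shown do not separate the share of the bromine in compound 2 from that of its methoxy group. They also leave open how an aryl group carrying an amine or a carboxylic acid would read at this place.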